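This account rests on a few compounds, and the source may have more. Where it says the series, first, only, none or still open, it means among the compounds named here.

Of the compounds shown here, two have numbers so far. Compound 1 `N#Cc1c(Oc2ccc(OC(F)(F)F)cc2)ccnc1N1CCC(NC(=S)Nc2cccnc2)CC1` gives 180 nM in an assay on membranes from brain for binding affinity to Lysophosphatidylserine lipase ABHD12 (Mus musculus), read by fluorescence, with a stated time of 20 min; on this read-out higher numbers stand for weaker inhibition and lower numbers for stronger inhibition. Compound 2 `S=C(Nc1cccnc1)NC1CCN(c2cc(OCc3ccccc3)ccn2)CC1` gives 2800 nM in this assay, the higher of the two numbers; the gap to compound 1 lies beyond the scatter. Among the compounds with values here, the two differ in more than one place, so no single step is drawn between them.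

Compound 3 `Fc1ccc(Oc2ccnc(N3CCC(NC(=S)Nc4cccnc4)CC3)c2)cc1` has not yet been measured in this assay. It differs from compound 2 by 4-fluorophenyl in place of benzyl on an oxygen on an aromatic ring. Within the data shown here, no step between measured compounds covers this change. Compound 1, the only other point, also carries an aromatic ring on that oxygen in place of a benzyl, but differs further in its nitrile and in the group on that ring, so its lower number is only a loose pointer.

The expected step from compound 2 to compound 3 is a 3.5-fold lower number from compound 2 to compound 3 (0.54 log units; beyond the scatter), toward a lower number, because compound 1 gives 180 nM. Compound 3 is estimated at 800 nM, with a range from 200 nM to 3000 nM.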

Compound 3, half-maximal inhibitory concentration: 1400 nM
Estimate against measurement, compound 3: 1.8-fold (0.24 log units) below; the measured number falls inside the stated range.
By their numbers in this assay, from the lowest: compound 1; then compounds 3 and 2 (each within the scatter of the next).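

In this assay, 4-fluorophenyl in place of benzyl on an oxygen on an aromatic ring gives a 2.0-fold lower number from compound 2 to compound 3 (0.30 log units; within the scatter), so on this read-out the change from benzyloxy to 4-fluorophenoxy does not separate the two compounds. Compound 1 at 180 nM differs from compound 3 in more than one place, so its value cannot be assigned to the nitrile or to the group on its aromatic ring. No supporting data bear on this result.

Going by these compounds, the nitrile and the trifluoromethoxy group remain open as separate single changes on the core of compound 3. Also open, on these data alone, is how an amine or a carboxylic acid on the aromatic ring, or a longer chain on the oxygen in place of benzyl, would read in this assay.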